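The source may hold more compounds than are shown below. What is called first, only, known or untested is meant among the compounds shown, and "the series" means these compounds.

In an ADME assay on MDCK cells (Canis lupus familiaris) for cytotoxicity, read by MTT assay, with a stated time of 48 h (a higher number here means that more compound is tolerated, a lower number that less compound is tolerated), compound 3 `FC(F)(F)c1ccccc1-c1cn(CC2=C(Cl)c3ccc(-c4cccs4)nc3CC2)nn1` gives > 300 ug/mL as a limit of the assay, not a number. Compound 1 `COc1ccc(-c2cn(CC3=C(Cl)c4ccc(-c5cccs5)nc4CC3)nn2)cc1` gives > 300 ug/mL as the same kind of limit. Compound 2 `Fc1ccc(-c2cn(CC3=C(Cl)c4ccc(-c5cccs5)nc4CC3)nn2)c(F)c1` gives a true number of 188 ug/mL in this series. Compound 4 `CCCCCc1cn(CC2=C(Cl)c3ccc(-c4cccs4)nc3CC2)nn1` differs from compound 3 by pentyl in place of 2-(trifluoromethyl)phenyl on an aromatic carbon and carries pentyl in place of 2-(trifluoromethyl)phenyl on an aromatic carbon. The measured steps at this place are an at least 1.5-fold lower number from compound 1 to compound 2 (0.20 log units; that floor lies within the scatter) and an at least 1.5-fold higher number from compound 2 to compound 3 (0.20 log units; that floor lies within the scatter) and also a step that the two limits leave unreadable from compound 1 to compound 3 in turn. Each swaps one phenyl group for another, so they guide only loosely. Expected in this assay is an at least 1.3-fold lower number from compound 3 to compound 4 (0.13 log units; that floor lies within the scatter) in the lower direction, a small move that may stay within the scatter. The estimate for compound 4 is 220 ug/mL with an expected range of 90 ug/mL to 400 ug/mL overall.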

Compound 4, half-maximal cytotoxic concentration: 50 ug/mL
Compound 4: middle estimate off by 4.4-fold (0.64 log units), on the high side; measured number below the stated range.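

Among the phenyl groups at this place on the five-membered ring, no swap gave a readable step beyond the scatter, but pentyl, which has no ring, gives a clear drop in this assay: an at least 6.0-fold lower number from compound 3 to compound 4 (0.77 log units; beyond the scatter), a 3.8-fold lower number from compound 2 to compound 4 (0.58 log units; beyond the scatter) and an at least 6.0-fold lower number from compound 1 to compound 4 (0.77 log units; beyond the scatter). Two of these sizes are only floors, because their starting values are limits of the assay: the limit of > 300 ug/mL in this assay, at which 2 of the 4 values shown sit.

Open, from the compounds shown here alone, is whether the drop follows from losing the aromatic ring or from the chain itself. A cyclohexyl group, a shorter butyl chain or a pentyl chain ending in an amine could separate these.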